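Phenoxy for phenyl on a pyrrolidine-ether stilbene pair

This account rests on a few compounds, and the source may have more. Where it says the series, first, only, none or still open, it means among the compounds named here.

Compound 1 `CC(C)(C)OC(=O)N1CCC[C@H]1COCCCCCCCCC/C=C/c1ccc(-c2ccccc2)cc1` is the tert-butyl carbamate member of the pair; in a functional assay on PANC-1 cells (Homo sapiens) for inhibition, read by XTT assay, with a stated time of 72 h (on this read-out higher numbers stand for weaker inhibition and lower numbers for stronger inhibition), compound 1 gives 80000 nM. Compound 2 `CC(C)(C)OC(=O)N1CCC[C@H]1COCCCCCCCCC/C=C/c1ccc(Oc2ccccc2)cc1` differs from it in one place (phenoxy in place of phenyl on an aromatic carbon). In this assay compound 2 reaches only a limit, > 100000 nM. The measured step of an at least 1.2-fold higher number from compound 1 to compound 2 (0.09 log units; that floor lies within the scatter) is therefore a floor, which rests on (the limit of > 100000 nM in this assay, at which 1 of the 3 values shown sits).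

Compound 3 `O=CN1CCC[C@H]1COCCCCCC/C=C/c1ccc(-c2ccccc2)cc1` carries a formyl group on the ring nitrogen and a shorter chain; how its core differs from the core of compound 1 is not broken down here. In this assay compound 3 gives 50000 nM, and the value of compound 1 lies within the scatter of it.

Compound 4 `O=CN1CCC[C@H]1COCCCCCC/C=C/c1ccc(Oc2ccccc2)cc1` has not been measured. It repeats, on the core of compound 3, the same change made from compound 1 to compound 2 (phenoxy in place of phenyl on an aromatic carbon), at a place described in the same words both times. For compound 4 a step of a 2.0-fold higher number from compound 3 to compound 4 (0.30 log units; within the scatter) is expected, weaker inhibition or a limit, resting on the floor an at least 1.2-fold higher number from compound 1 to compound 2 (0.09 log units; that floor lies within the scatter) set by compound 2. Compound 4 is estimated at 100000 nM, from 50000 nM to 250000 nM.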

Compound 4, half-maximal inhibitory concentration: 53300 nM
Compound 4: the middle estimate sits 1.9-fold (0.27 log units) above what was measured; the range from low to high includes it.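

In this assay, phenoxy in place of phenyl on the core of compound 3 gives a 1.1-fold higher number from compound 3 to compound 4 (0.03 log units; within the scatter), so on this core the change produces no step beyond the scatter, and the added oxygen, counted as one hydrogen-bond acceptor, brings no readable shift in inhibition. Compound 2 stands only at a limit, > 100000 nM, so the step on the core of compound 1 is a floor and not a size: the limit of > 100000 nM in this assay, at which 1 of the 4 values shown sits. Two cores therefore show no sign of a large gain from the change, but they do not show that it carries over with the same size, nor with a different one: the same change on two cores in this assay, an at least 1.2-fold higher number (0.09 log units; that floor lies within the scatter) from compound 1 to compound 2 and a 1.1-fold higher number (0.03 log units; within the scatter) from compound 3 to compound 4; the limit leaves it open whether they differ.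

The compounds shown leave open whether the step would stay within the scatter with a free amine or an acetyl group on the ring nitrogen, or with a longer chain on the formyl core. They also leave open how a benzyloxy or anilino group would compare with phenoxy on either core.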